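Phenoxy for 4-methoxyphenyl on the shared core

The source may report more compounds than this note shows. Statements on the series, on what has been measured and on what is new or still open speak of the compounds shown alone.

Compound 3 `COc1ccc(-c2ccc3c(NCCCNCc4cc(F)ccc4OC)ccnc3c2)cc1` gives 32000 nM in a physicochemical assay for solubility, with a stated time of 18 h, at pH 7.4 (a higher number here means a more soluble compound, a lower number a less soluble compound), level with compound 1 `COc1ccc(F)cc1CNCCCNc1ccnc2cc(-c3ccc(F)cc3)ccc12` at 32000 nM and compound 2 `COc1ccc(F)cc1CNCCCNc1ccnc2cc(-c3ccccc3)ccc12` at 32000 nM. The measured steps, no change at the digits printed from compound 1 to compound 2 (within the scatter), no change at the digits printed from compound 1 to compound 3 (within the scatter) and no change at the digits printed from compound 2 to compound 3 (within the scatter), each change a single substituent on the outer aromatic ring and none moves this assay beyond the scatter. Compound 4 `COc1ccc(F)cc1CNCCCNc1ccnc2cc(Oc3ccccc3)ccc12` differs from compound 3 by phenoxy in place of 4-methoxyphenyl on an aromatic carbon; the ring is now attached through an oxygen. Within the data shown here, no measured step covers such an exchange, so the expectation rests on the flat pattern across compounds 1, 2 and 3. A step of no change at the digits printed from compound 3 to compound 4 (within the scatter) is therefore expected, no change beyond the scatter. For compound 4 the estimate in this assay is 32000 nM, within 14000 nM to 64000 nM.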

Compound 4, solubility: 14500 nM
Beside the measured number, compound 4's estimate is 2.2-fold (0.34 log units) above it, and the stated range covers the measured number.
By their numbers in this assay, from the lowest: compound 4; then compounds 1, 2 and 3 (each within the scatter of the next).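

In this assay, among these compounds, the phenoxy exchange is the first change at this position to go beyond the scatter: a 2.2-fold lower number from compound 3 to compound 4 (0.34 log units; beyond the scatter) and a 2.2-fold lower number from compound 2 to compound 4 (0.34 log units; beyond the scatter) and a 2.2-fold lower number from compound 1 to compound 4 (0.34 log units; beyond the scatter) are all modest. The steps among compounds 1, 2 and 3 altered only a substituent on the outer ring, whereas these attach the ring through an oxygen. Nothing measured here accounts for the lower numbers.

On these data alone, it remains open whether an anilino or benzyl group at this position gives a similar step. Whether 4-fluorophenoxy or 4-methoxyphenoxy would stay level with phenoxy is also unsettled.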